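Aryl ether hydrazones: nitro for methyl

A few compounds are considered here, and "the series" means these few. Any claim that something is new, unique, unknown or untested is made for them only; others in the source may bear on it.

Measured compounds:
compound 1, `O=C(N/N=C\c1ccc(Oc2ccc(Cl)cc2)cc1)c1ccncc1`, 3.95
compound 2, `Cc1cc(Oc2ccc(/C=N\NC(=O)c3ccncc3)cc2)ccc1Cl`, 4.22
compound 3, `Cc1ccc(Oc2ccc(/C=N\NC(=O)c3ccncc3)cc2)cc1`, 3.65

In a physicochemical assay for lipophilicity, in phosphate buffer, measured as octanol-water partition, with a stated time of 24 h (on this read-out higher numbers stand for higher lipophilicity and lower numbers for lower lipophilicity), compound 3 gives the lowest of the three numbers. Its gap to compound 1 is within the scatter; its gap to compound 2 is beyond it (a number 0.57 log units lower from compound 2 to compound 3 (beyond the scatter)).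

Compound 4, `O=C(N/N=C\c1ccc(Oc2ccc([N+](=O)[O-])cc2)cc1)c1ccncc1`, is not yet measured. It differs from compound 3 by nitro in place of methyl on an aromatic carbon; the place is on an aromatic carbon of a six-membered aromatic ring of carbon only, para to a large group.

Going by the values given here, no measured step contains a nitro group, so the known steps bear on this one only indirectly. Swapping substituents on the same ring carbon moved the read-out by a number 0.30 log units lower from compound 1 to compound 3 (within the scatter) and adding a methyl gave a number 0.27 log units higher from compound 1 to compound 2 (within the scatter), both within the scatter; only the combined change a number 0.57 log units lower from compound 2 to compound 3 (beyond the scatter) went beyond it. Replacing a methyl by a nitro group is expected to lower the read-out more than those swaps did.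

Compound 4 is therefore estimated at 3.05, with a range of 2.65 to 3.5, an expected step of a number 0.60 log units lower from compound 3 to compound 4 (beyond the scatter).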

Compound 4, partition coefficient: 3.23
Estimate against measurement, compound 4: 0.18 log units below; the measured number falls inside the stated range.
By their numbers in this assay, from the lowest: compound 4; then compounds 3, 1 and 2 (each within the scatter of the next, the first and the last beyond it).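

In this assay, a single exchange at this aromatic carbon, para to a large group, now gives a step beyond the scatter (nitro for methyl: a number 0.42 log units lower from compound 3 to compound 4 (beyond the scatter); nitro for chloro: a number 0.72 log units lower from compound 1 to compound 4 (beyond the scatter)), whereas methyl for chloro at the same place stayed within it (a number 0.30 log units lower from compound 1 to compound 3 (within the scatter)). Compound 4 sits lowest of the four, and the exchange of 4-chloro-3-methylphenyl for 4-nitrophenyl gives the largest gap in the set (a number 0.99 log units lower from compound 2 to compound 4 (beyond the scatter)). No measurement shown here accounts for the size of these steps.

As far as these compounds go, whether an amine or a carboxylic acid at this place would fall below compound 4 remains open. Also open, from the compounds shown here alone, is whether the extra methyl seen in compound 2 would shift a nitro compound in the same direction.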